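From isobutyl to tert-butyl on the shared core

A few compounds are considered here, and "the series" means these few. Any claim that something is new, unique, unknown or untested is made for them only; others in the source may bear on it.

In a functional assay on the whole organism with Scenedesmus acutus as the target, with a stated time of 20 h (a higher number here means a weaker inhibitor, a lower number a stronger inhibitor), compound 1 `O=C(O)c1cc(N2C(=O)C3=C(CCCC3)C2=O)ccc1Cl` reaches only an assay limit, > 100000 nM.

Compound 2 `COC(=O)c1cc(N2C(=O)C3=C(CCCC3)C2=O)ccc1Cl` gives 1620 nM and compound 3 `CC(C)COC(=O)c1cc(N2C(=O)C3=C(CCCC3)C2=O)ccc1Cl` gives 15500 nM. Compound 3 therefore holds the higher of the two actual numbers, and its gap to compound 2 lies beyond the scatter.

Compound 4 `CC(C)(C)OC(=O)c1cc(N2C(=O)C3=C(CCCC3)C2=O)ccc1Cl` is not yet measured. It carries tert-butyl in place of isobutyl on an oxygen next to a carbonyl group, (tert-butyl in place of isobutyl on an oxygen next to a carbonyl group).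

The closest guide is a 9.6-fold higher number from compound 2 to compound 3 (0.98 log units; beyond the scatter), where isobutyl replaces methyl. The steps of an at least 61-fold lower number from compound 1 to compound 2 (1.79 log units; beyond the scatter) and an at least 6.4-fold lower number from compound 1 to compound 3 (0.80 log units; beyond the scatter) both start from the hydrogen and bear less directly. Among the compounds with values here, no measured step compares two groups with the same atoms joined differently, so the size of this change remains open.

No step beyond the scatter is expected, and neither direction is favoured. The expected change is a 1.0-fold lower number from compound 3 to compound 4 (0.01 log units; within the scatter).

For compound 4, the estimate is 15000 nM, with an expected range of 4000 nM to 60000 nM.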

Compound 4, half-maximal inhibitory concentration: > 100000 nM
Compound 4 ended at the assay's limit; the forecaster's own chance of this, stated with the estimate: 10%; middle value at least 6.6-fold (0.82 log units) from the limit.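

In this assay, tert-butyl in place of isobutyl on an oxygen next to a carbonyl group is not a silent exchange, although the two groups hold the same atoms joined differently: the result is an at least 6.4-fold higher number from compound 3 to compound 4 (0.80 log units; beyond the scatter). Against methyl on the same oxygen, tert-butyl gives an at least 61-fold higher number from compound 2 to compound 4 (1.79 log units; beyond the scatter), so the arrangement of the carbons in this group moves the number, not the carbon count alone. The step between compound 1 and compound 4 cannot be read, since both ends are limits: the limit of > 100000 nM in this assay, at which 2 of the 4 values shown sit.

From the compounds shown here alone, whether ethyl or a straight butyl chain on this oxygen stays close to compound 2 or to compound 3 remains open. Also open, going by these compounds, is how an amide nitrogen in place of this oxygen would read in this assay.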